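Working notes: amine substituent exchange, compound 2 to compound 3

The source may report more compounds than this note shows. Statements on the series, on what has been measured and on what is new or still open speak of the compounds shown alone.

Of the compounds shown here, two carry numbers so far. Compound 1 `CN1CCN(c2ccc(C(=O)/C=C/c3ccc(Cl)cc3)cc2)CC1` in an ADME assay on Vero cells (Chlorocebus sabaeus) for cytotoxicity, with a stated time of 72 h (a higher number here means that more compound is tolerated, a lower number that less compound is tolerated), gives 102 ug/mL. Compound 2 `CCCCNc1ccc(C(=O)C2CC2c2ccc(Cl)cc2)cc1` in this assay gives 316 ug/mL. Compound 2 therefore stands highest of the two numbers; its nearest neighbour is compound 1, whose number is lower, and the gap between the two values lies beyond the scatter. For the measured compounds named here, compound 1 and compound 2 differ in more than one place, so no single structural step connects them, and only the two values themselves can be read.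

Compound 3 `O=C(c1ccc(NCc2ccco2)cc1)C1CC1c1ccc(Cl)cc1` keeps everything of compound 2 except one spot: furan-2-yl in place of propyl on a saturated chain carbon bound to a nitrogen on an aromatic ring. Going by the values given here, nothing among the measured compounds isolates this change, so no step size can be drawn from them. In this assay the step is expected to be small, if anything a slight fall in tolerated concentration, and quite possibly none beyond the scatter. For compound 3 the expected value is estimated at 250 ug/mL, within a range from 100 ug/mL to 500 ug/mL. That estimate corresponds to an expected step of a 1.3-fold lower number from compound 2 to compound 3 (0.10 log units; within the scatter).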

Compound 3, half-maximal cytotoxic concentration: 256 ug/mL
Compound 3: the middle estimate sits 1.0-fold (0.01 log units) below what was measured; the range from low to high includes it.
By their numbers in this assay, from the lowest: compound 1; then compounds 3 and 2 (each within the scatter of the next).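

For the compounds shown here, the exchange of furan-2-yl for propyl on a saturated chain carbon bound to a nitrogen on an aromatic ring gives the first single-place step: in this assay, it amounts to a 1.2-fold lower number from compound 2 to compound 3 (0.09 log units; within the scatter). This place therefore accepts one five-membered aromatic ring with 1 hetero atom and 1 hydrogen-bond acceptor in place of an open chain with no ring and no acceptor, and this assay does not separate the two compounds. No independent measurement bears on why the read-out stays within the scatter across this exchange.

This single step cannot show whether the tolerance at this place extends to other groups, such as a carboxylic acid, a tertiary amine or a longer chain, on the same saturated carbon. It also leaves open whether the exchange of propyl for furan-2-yl would read the same on the core of compound 1, which differs from compound 2 in more than one place and so offers no comparison here.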